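Swapping the anilide aryl group on a chromone acrylamide

This account rests on a few compounds, and the source may have more. Where it says the series, first, only, none or still open, it means among the compounds named here.

The three measured compounds share a chromone acrylamide core and differ in the aryl group on the amide nitrogen and in the substituent on the core. Compound 1 `COc1ccc2c(=O)c(/C=C/C(=O)Nc3ccccc3Cl)coc2c1` gives 23000 nM in a functional assay (QGY7701 cells, Homo sapiens) for inhibition, read by MTT assay, with a stated time of 48 h; on this read-out higher numbers stand for weaker inhibition and lower numbers for stronger inhibition. Compound 3 `O=C(/C=C/c1coc2cc(O)ccc2c1=O)Nc1ccccc1` gives 17900 nM in this assay, and its value and that of compound 1 sit within the scatter of each other. Compound 2 `COc1ccc(NC(=O)/C=C/c2coc3cc(O)ccc3c2=O)cc1` reaches only the limit of > 100000 nM in this assay, a limit and not a number; the relevant evidence is the limit of > 100000 nM in this assay, at which 1 of the 3 values shown sits.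

Going by the values given here, the one single-point step in the set is an at least 5.5-fold lower number from compound 2 to compound 3 (0.74 log units; beyond the scatter), hydrogen in place of methoxy on an aromatic carbon, an at least modest step that shows the 4-methoxyphenyl anilide faring worse than the plain phenyl anilide.

Compound 4 `CCOc1ccc(NC(=O)/C=C/c2coc3cc(OC)ccc3c2=O)cc1` is compound 1 with 4-ethoxyphenyl in place of 2-chlorophenyl on an amide-type nitrogen. The entering group carries an alkoxy on the aryl ring, as compound 2 does, so the step from compound 2 to compound 3, read backwards, is the closest guide, though the core substituent and the chain length differ. The expected step is a 3.5-fold higher number from compound 1 to compound 4 (0.54 log units; beyond the scatter), towards a weaker inhibition, with a real chance that only a limit results. Compound 4 is therefore expected to give about 80000 nM in this assay, within 25000 nM to 300000 nM.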

Compound 4, half-maximal inhibitory concentration: > 100000 nM
Compound 4 gave a limit, no number; the forecaster's own chance of this, stated with the estimate: 45%; middle value at least 1.2-fold (0.09 log units) from the limit.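

The change to 4-ethoxyphenyl in place of 2-chlorophenyl on an amide-type nitrogen gives an at least 4.3-fold higher number from compound 1 to compound 4 (0.63 log units; beyond the scatter), so the aryl group at this place moves the read-out on a second core and not only on the core shared by the earlier pair. Compound 4 ends at a limit and not a number, as compound 2 does, so both anilides with an alkoxy on the aryl ring sit at that limit, and no compound shown goes against this: the limit of > 100000 nM in this assay, at which 2 of the 4 values shown sit. On this core, the 2-chlorophenyl group keeps a measurable value while the 4-ethoxyphenyl group does not, though the data give no cause for the difference.

From the compounds shown here alone, whether the step comes from gaining the alkoxy or from losing the chlorine stays open, since both change at once and the limit hides the full size of the step. Nor do the compounds shown tell how an amine or a carboxylic acid on this aryl ring would read in this assay, or what the substituent on the core does when it alone is changed.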